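This account rests on a few compounds, and the source may have more. Where it says the series, first, only, none or still open, it means among the compounds named here.

Measured compounds in an ADME assay on HEK293 cells for agonist activity at metabotropic glutamate receptor 5 (Rattus norvegicus), read by fluorescence and calcium flux; on this read-out higher numbers stand for larger maximal responses and lower numbers for smaller maximal responses: compound 1 `C[C@@H](NC(=O)c1ccc(C#Cc2cc(F)cc(F)c2)cn1)C(C)(C)O` gives 37.9%; compound 2 `C[C@@H](NC(=O)c1ccc(C#Cc2ccc(F)cc2F)cn1)C(C)(C)O` gives 38.2%.

Compound 2 and compound 1 sit within the usual scatter of each other, as a number 0.3 percentage points higher from compound 1 to compound 2 (within the scatter) shows. Compound 3 `Cc1ccccc1C#Cc1ccc(C(=O)N[C@H](C)C(C)(C)O)nc1` differs from compound 2 by 2-methylphenyl in place of 2,4-difluorophenyl on a triple-bonded carbon. Going by the values given here, the only measured step swaps one difluorophenyl pattern for another and stayed within the scatter; no measured step exchanges fluorine for a methyl group, so the data give no direct guide. Compound 3 is therefore expected to show no step beyond the scatter, a number 2.2 percentage points lower from compound 2 to compound 3 (within the scatter), with wide uncertainty. The estimate for compound 3 is 36%, between 18% and 55%.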

Compound 3, largest response reached (reported as efficacy), in percent of the reference or control that the assay uses: 24.1%
Compound 3: the middle estimate sits 11.9 percentage points above what was measured, and the stated range covers the measured number.
By their numbers in this assay, from the lowest: compound 3; then compounds 1 and 2 (each within the scatter of the next).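

At this place on the triple-bonded carbon, the response in this assay does depend on the aromatic group: 2-methylphenyl gives a number 14.1 percentage points lower from compound 2 to compound 3 (beyond the scatter) and a number 13.8 percentage points lower from compound 1 to compound 3 (beyond the scatter) even though the two fluorine patterns could not be told apart. This change removes both fluorines and brings in a methyl group at once, so the compounds cannot separate the two contributions. Nothing available explains the lower response. As far as these compounds go, it remains open whether the methyl group or the missing fluorines account for the step. An unsubstituted phenyl or a 2-fluorophenyl on the same carbon would address that question.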